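Aryl replacement on the shared core: compound 4

The compounds below may be only part of what the source reports. "The series", "measured", "known", "first", "only" and "open" are said of these compounds alone.

Compound 3 `CC(C)(C)n1ncc(OCc2nnc(-c3ccc(F)cc3)o2)c(Cl)c1=O` holds the weaker of the two measured numbers in a functional assay on the whole organism for inhibition, with Mythimna separata as the target, with a stated time of 5 days; on this read-out lower numbers stand for an effect already at smaller amounts and higher numbers for an effect only at larger amounts of compound: compound 3 gives 5200 nM. Compound 2 `CC(C)(C)n1ncc(OCc2nnc(-c3ccc(Cl)cc3)o2)c(Cl)c1=O` gives 1900 nM, the nearest value, separated by a 2.7-fold higher number from compound 2 to compound 3 (0.44 log units; beyond the scatter). Compound 1 `Cc1cc(C)cc(-c2nnc(COc3cnn(C(C)(C)C)c(=O)c3Cl)o2)c1` returns only a limit of the assay and not a number, > 299000 nM; this is the limit of > 299000 nM in this assay, at which 1 of the 3 values shown sits. Against that limit, the moves to a halogenated phenyl were large: an at least 150-fold lower number from compound 1 to compound 2 (2.19 log units; beyond the scatter) and an at least 57-fold lower number from compound 1 to compound 3 (1.75 log units; beyond the scatter).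

Compound 4 `CC(C)(C)n1ncc(OCc2nnc(-c3ccco3)o2)c(Cl)c1=O` differs from compound 3 in one place: furan-2-yl in place of 4-fluorophenyl on an aromatic carbon. Among the measured compounds shown here, no measured step carries a five-membered heteroaryl in this place, so the measured steps bear on it only indirectly. They show the aryl group to be the part that moves this assay most, with the difference between the two halophenyls modest (a 2.7-fold higher number from compound 2 to compound 3 (0.44 log units; beyond the scatter)) and the step from 3,5-dimethylphenyl large. A step of modest to large size toward a higher number is expected for compound 4, a 2.9-fold higher number from compound 3 to compound 4 (0.46 log units; beyond the scatter). Compound 4 is estimated at 15000 nM in this assay, with a range from 4000 nM to 60000 nM.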

Compound 4, half-maximal effective concentration: > 299000 nM
Compound 4: only a limit was reported; the forecaster's own chance of this, stated with the estimate: 15%; middle value at least 19-fold (1.29 log units) from the limit.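

Furan-2-yl in place of a halogenated phenyl on this aromatic carbon takes the read-out in this assay from a number to a limit, with steps of an at least 57-fold higher number from compound 3 to compound 4 (1.75 log units; beyond the scatter) and an at least 150-fold higher number from compound 2 to compound 4 (2.19 log units; beyond the scatter). Compound 4 gives only a limit of the assay, > 299000 nM, and not a number. Among the compounds shown, measured numbers occur only with 4-chlorophenyl and 4-fluorophenyl at this place, while 3,5-dimethylphenyl in compound 1 and furan-2-yl in compound 4 both end at the same limit: the limit of > 299000 nM in this assay, at which 2 of the 4 values shown sit.

The step between compound 1 and compound 4 cannot be read, with a limit at both ends, so these two groups stay unordered. Still open, from the compounds shown here alone, is whether unsubstituted phenyl, thiophen-2-yl or a chloro-substituted furan at this place returns a number in this assay.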